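The source may report more compounds than this note shows. Statements on the series, on what has been measured and on what is new or still open speak of the compounds shown alone.

Of the compounds shown here, three have so far been tested in a functional assay on A549 cells (Homo sapiens) for cytotoxicity, read by MTT assay, with a stated time of 24 h; a higher number here means a weaker inhibitor, a lower number a stronger inhibitor. Compound 1 `CCOC(=O)N1CCC(=NNC(=O)c2ccc(F)cc2)CC1` returns only a limit in this assay, > 400000 nM, and not a measured number. Compound 2 `CCOC(=O)N1CCC(=NNC(=O)c2ccc(C(F)(F)F)cc2)CC1` gives a measured value in this assay of 37100000 nM. The change between them is trifluoromethyl in place of fluoro on an aromatic carbon, a step whose size the limit leaves unreadable a step that the limit leaves unreadable from compound 1 to compound 2. Compound 3 `COc1ccc(C(=O)NN=C2CC(c3ccccc3)NC(c3ccccc3)C2)cc1` also stands at a limit in this assay, > 400000 nM. That limit is the limit of > 400000 nM in this assay, at which 2 of the 3 values shown sit, so the standing of compound 3 against the others cannot be resolved further.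

Compound 4 `O=C(NN=C1CC(c2ccccc2)NC(c2ccccc2)C1)c1ccc(F)cc1C(F)(F)F` differs from compound 3 by 4-fluoro-2-(trifluoromethyl)phenyl in place of 4-methoxyphenyl on a carbonyl carbon. Among the compounds with values here, the only measured step is the unreadable one, so no size can be borrowed from it for this change. Compound 4 is therefore expected, like compound 3, to sit near or at the limit, with an estimated value of 2000000 nM and a range from 400000 nM to 40000000 nM. The expected step is a step that the limit leaves unreadable from compound 3 to compound 4.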

Compound 4, half-maximal inhibitory concentration: > 400000 nM
Compound 4 ended at the assay's limit (the forecaster's own chance of this, stated with the estimate: 55%); the middle value lies beyond the limit too.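

No step can be read from compound 3 to compound 4, since both stand at a limit in this assay and not at a measured number: the limit of > 400000 nM in this assay, at which 3 of the 4 values shown sit. The compounds shown leave open whether 4-fluoro-2-(trifluoromethyl)phenyl in place of 4-methoxyphenyl changes cytotoxicity at all.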